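The compounds below may be only part of what the source reports. "The series", "measured", "known", "first", "only" and "open" are said of these compounds alone.

In an ADME assay on microsomes from liver (Mus musculus, strain CD-1) for metabolic stability, read by LC-MS, tested at 2 uM (on this read-out higher numbers stand for a longer-lived compound and lower numbers for a shorter-lived compound), the compounds measured so far read:

Compound 1 `CN1CCCC(NS(=O)(=O)c2ccccc2Nc2cc(-c3ccc4ccn(C)c4c3)c3nccnc3c2)C1` gives 0.483 h 
Compound 2 `Cn1ccc2ccc(-c3cc(Nc4ccccc4S(=O)(=O)NCC4CCOCC4)cc4nccnc34)cc21` gives 0.3 h 
Compound 3 `Cn1cc(NC(=O)c2ccncc2Nc2cc(-c3ccc4ccn(C)c4c3)c3nccnc3c2)cn1` gives 0.2 h 

Compound 3 (0.2 h) has the lower number against compound 1 (0.483 h) by more than the scatter, and it lies within the scatter of compound 2 (0.3 h) .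

Compound 4 `CC(=O)N1CCCC(NC(=O)c2ccncc2Nc2cc(-c3ccc4ccn(C)c4c3)c3nccnc3c2)C1` keeps the core of compound 3 and changes one group: 1-acetylpiperidin-3-yl in place of 1-methyl-1H-pyrazol-4-yl on an amide-type nitrogen. A six-membered non-aromatic ring thus replaces a five-membered aromatic ring on the amide-type nitrogen.

Among the measured compounds shown here, only one measured step bears on this, and only loosely: a 1.6-fold lower number from compound 1 to compound 2 (0.21 log units; within the scatter). It lies within the scatter, sits on a sulfonamide nitrogen, and involves neither group of the present change. With nothing larger to go on, no step beyond the scatter is expected.

The expected step is small: a 1.4-fold higher number from compound 3 to compound 4 (0.13 log units; within the scatter).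

For compound 4 the estimated half-life is 0.27 h (expected range 0.13 h to 0.55 h) .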

Compound 4, half-life: 0.4 h
Beside the measured number, compound 4's estimate is 1.5-fold (0.17 log units) below it; low and high end bracket the measured number.
By their numbers in this assay, from the lowest: compounds 3, 2, 4 and 1 (each within the scatter of the next, the first and the last beyond it).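

On the amide-type nitrogen, 1-acetylpiperidin-3-yl in place of 1-methyl-1H-pyrazol-4-yl gives a 2.0-fold higher number from compound 3 to compound 4 (0.30 log units; within the scatter) in this assay. Among the compounds shown here, this is the first step read at this position, and it shows that a six-membered non-aromatic ring can take the place of a five-membered aromatic ring there with no step beyond the scatter, as with the one earlier step, on a sulfonamide nitrogen, a 1.6-fold lower number from compound 1 to compound 2 (0.21 log units; within the scatter). Nothing measured here explains the half-lives of these compounds.

As far as these compounds go, it remains open whether the acetyl group or the ring itself matters at this position, which a piperidine carrying a free secondary amine could help to separate. From the compounds shown here alone, whether a simple phenyl ring on the same nitrogen would read any differently also remains open.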